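Urea substitution on the pyrrolidine ring of compound 1

A few compounds are considered here, and "the series" means these few. Any claim that something is new, unique, unknown or untested is made for them only; others in the source may bear on it.

Measured so far:
- compound 1, `CC1CCN(c2ccc3cc(NC(=O)CCc4ccc(C(F)(F)F)cc4)ccc3n2)C1`: 400 nM
- compound 2, `O=C(CCc1ccc(C(F)(F)F)cc1)Nc1ccc2nc(N3CCCCC3)ccc2c1`: 110 nM

In a functional assay on HEK293 cells for activation of melanin-concentrating hormone receptor 1 (Rattus norvegicus), read by inositol phosphate accumulation (on this read-out lower numbers stand for an effect already at smaller amounts and higher numbers for an effect only at larger amounts of compound), compound 1 gives 400 nM and stands highest of the two numbers. Among the compounds with values here, its nearest neighbour is compound 2, which in this assay gives 110 nM; the one measured step is a 3.6-fold lower number from compound 1 to compound 2 (0.56 log units; beyond the scatter), a change at the ring on the aromatic carbon.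

Compound 3 is `CNC(=O)NC1CCN(c2ccc3cc(NC(=O)CCc4ccc(C(F)(F)F)cc4)ccc3n2)C1`. It differs from compound 1 by (methylcarbamoyl)amino in place of methyl on a saturated ring carbon, cut one bond further out: 3-methylpyrrolidin-1-yl to 3-((methylcarbamoyl)amino)pyrrolidin-1-yl. Within the data shown here, no measured step touches a substituent on the saturated ring carbon; the step from compound 1 to compound 2 changes the ring itself and does not tell how a group on the five-membered ring behaves. The expectation in this assay is therefore centred on no step beyond the scatter, with wide bounds in both directions. Compound 3 is estimated at 400 nM (range 100 nM to 1600 nM), which means an expected step of no change at the digits printed from compound 1 to compound 3 (within the scatter).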

Compound 3, half-maximal effective concentration: 30 nM
For compound 3 the middle estimate is 13-fold (1.12 log units) above the measured one, and the stated range ends above it.
By their numbers in this assay, from the lowest: compound 3; then compound 2; then compound 1.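

In this assay, within the data shown here, the saturated ring carbon is not a silent position: (methylcarbamoyl)amino in place of methyl gives a 13-fold lower number from compound 1 to compound 3 (1.12 log units; beyond the scatter) and is the first measured change at this carbon. The pyrrolidine also need not give way to the six-membered ring, since 3-((methylcarbamoyl)amino)pyrrolidin-1-yl in place of piperidin-1-yl gives a 3.7-fold lower number from compound 2 to compound 3 (0.56 log units; beyond the scatter) and so reverses the order seen with the methyl group. No supporting evidence bears on why this substituent lowers the number.

Still open, as far as these compounds go, is how much of the step needs the whole (methylcarbamoyl)amino group, as against a plain amino group or an acetamide on the same ring carbon. Also open, from the compounds shown here alone, is whether a longer chain on the terminal urea nitrogen, such as ethyl or propyl, keeps the lower number.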